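The source may hold more compounds than are shown below. What is called first, only, known or untested is meant among the compounds shown, and "the series" means these compounds.

Compound 2 `COc1cccc(Br)c1-c1nc(CN2CCC(C(=O)NCCCN3C[C@H](C)C[C@H](C)C3)CC2)c(C)o1` gives 0.0583 h in an ADME assay on microsomes from liver (Rattus norvegicus) for metabolic stability, read by LC-MS, using NADPH, at 37 degrees C (on this read-out lower numbers stand for a shorter-lived compound and higher numbers for a longer-lived compound), the lower of the two numbers in hand; compound 1 `Cc1oc(-c2c(F)cccc2F)nc1CN1CCC(C(=O)NCCCN2C[C@H](C)C[C@H](C)C2)CC1` gives 0.35 h. Compound 3 `COc1cccc(OC)c1-c1nc(CN2CCC(C(=O)NCCCN3C[C@H](C)C[C@H](C)C3)CC2)c(C)o1` differs from compound 2 by methoxy in place of bromo on an aromatic carbon. Among the measured compounds shown here, no measured step swaps these two groups directly; the only step available, a 6.0-fold lower number from compound 1 to compound 2 (0.78 log units; beyond the scatter), altered two groups at once rather than one, so it offers only a loose guide. A small step is expected, a 1.7-fold higher number from compound 2 to compound 3 (0.23 log units; within the scatter), with no firm direction. Compound 3 is therefore estimated at 0.1 h, within 0.03 h to 0.3 h.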

Compound 3, half-life: 0.2 h
Beside the measured number, compound 3's estimate is 2.0-fold (0.30 log units) below it, and the stated range covers the measured number.
By their numbers in this assay, from the lowest: compound 2; then compounds 3 and 1 (each within the scatter of the next).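

In this assay, methoxy in place of bromo on this aromatic carbon, ortho to a large group, gives a 3.4-fold higher number from compound 2 to compound 3 (0.54 log units; beyond the scatter) and so shows that this single change moves the half-life beyond the scatter. The 2,6-dimethoxyphenyl and 2,6-difluorophenyl groups, by contrast, cannot be told apart here, with a 1.8-fold lower number from compound 1 to compound 3 (0.24 log units; within the scatter) as the step between them. No measured evidence accounts for either result. From the compounds shown here alone, whether chloro, methyl or trifluoromethyl in this place would give a half-life like that of compound 2 or that of compound 3 stays open.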